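This account rests on a few compounds, and the source may have more. Where it says the series, first, only, none or still open, it means among the compounds named here.

Measured so far in a functional assay on HeLa cells (Homo sapiens) for cytotoxicity, with a stated time of 72 h; on this read-out lower numbers stand for stronger inhibition and higher numbers for weaker inhibition:
compound 1 `Clc1ccc(Cc2nn3c(Br)c(-c4ccc(Cl)cc4)nc3s2)cc1` gives > 250000 nM
compound 2 `Clc1ccc(Cc2nn3c(Br)c(-c4ccc(Br)cc4)nc3s2)cc1` gives 188000 nM
compound 3 `N#CSc1c(-c2ccc(Cl)cc2)nc2sc(Cc3ccc(Cl)cc3)nn12` gives 20000 nM

The entry for compound 1 is a limit of the assay and not a number: the limit of > 250000 nM in this assay, at which 1 of the 3 values shown sits.

Compound 1 and compound 2 share one core and differ only in bromo in place of chloro on an aromatic carbon. That change gives an at least 1.3-fold lower number from compound 1 to compound 2 (0.12 log units; that floor lies within the scatter).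

Compound 3 differs from compound 1 at the core, by cyanosulfanyl in place of bromo on an aromatic carbon. This step is an at least 12-fold lower number from compound 1 to compound 3 (1.09 log units; beyond the scatter), and compound 3 has the lowest of the two numbers shown.

Compound 4 `N#CSc1c(-c2ccc(Br)cc2)nc2sc(Cc3ccc(Cl)cc3)nn12` is not yet measured. It differs from compound 3 by bromo in place of chloro on an aromatic carbon, the same change that turns compound 1 into compound 2, made on the core of compound 3. Since that change gave an at least 1.3-fold lower number from compound 1 to compound 2 (0.12 log units; that floor lies within the scatter), a step of about the same small size is expected here, a 1.3-fold lower number from compound 3 to compound 4 (0.12 log units; within the scatter), which rests only on that one pair. For compound 4 the expected number is 15000 nM, most likely between 7000 nM and 40000 nM.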

Compound 4, half-maximal inhibitory concentration: 22000 nM
The estimate for compound 4 lay 1.5-fold (0.17 log units) below the measured number; measured number inside the range.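

In this assay, bromo in place of chloro on the core of compound 3 gives a 1.1-fold higher number from compound 3 to compound 4 (0.04 log units; within the scatter), so 4-chlorophenyl to 4-bromophenyl makes no readable difference on this core, and the comparison with the earlier pair cannot be closed: the same change on two cores in this assay, an at least 1.3-fold lower number (0.12 log units; that floor lies within the scatter) from compound 1 to compound 2 and a 1.1-fold higher number (0.04 log units; within the scatter) from compound 3 to compound 4; the limit leaves it open whether they differ. Cyanosulfanyl in place of bromo, now tried on a second core, gives an 8.5-fold lower number from compound 2 to compound 4 (0.93 log units; beyond the scatter), so this change lowers the number on both cores, while any difference in the size of the two steps remains unsettled: the same change on two cores in this assay, an at least 12-fold lower number (1.09 log units; beyond the scatter) from compound 1 to compound 3 and an 8.5-fold lower number (0.93 log units; beyond the scatter) from compound 2 to compound 4; the limit leaves it open whether they differ. Compound 1 gives > 250000 nM, which is a limit of the assay and not a number, and two pairs of compounds show nothing about how either change behaves on cores beyond these.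

As far as these compounds go, only chloro and bromo appear on this aromatic ring, so it remains open how a fluoro or a methoxy group there would compare. From the compounds shown here alone, it also remains open whether an amine or a methylsulfanyl group in place of cyanosulfanyl would keep the lower numbers.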